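Trifluoromethyl for fluoro on a methylsulfonyl aniline scaffold

The source may report more compounds than this note shows. Statements on the series, on what has been measured and on what is new or still open speak of the compounds shown alone.

Within the data shown here, compound 1 `CS(=O)(=O)c1ccc(F)cc1NCC1=NCCN1` is one of two compounds measured in an assay for binding affinity to Alpha-1B adrenergic receptor (Homo sapiens), read by radioligand binding (on this read-out lower numbers stand for stronger inhibition and higher numbers for weaker inhibition), where compound 1 gives 1320 nM, the higher of the two numbers. Among the measured compounds shown here, its neighbour compound 2 `CSc1ccc(F)cc1NCC1=NCCN1` gives 40.7 nM in this assay, and the single step between them, a 32-fold lower number from compound 1 to compound 2 (1.51 log units; beyond the scatter), concerns methylsulfanyl in place of methylsulfonyl on an aromatic carbon. Compound 3 `CS(=O)(=O)c1ccc(C(F)(F)F)cc1NCC1=NCCN1` keeps the methylsulfonyl group of compound 1 and changes a different position: trifluoromethyl in place of fluoro on an aromatic carbon, on an aromatic carbon of the six-membered aromatic ring, para to a methylsulfonyl group. For the measured compounds named here, the one measured step does not touch this position, so nothing among the measured compounds speaks to the size or direction of this change in this assay. In the absence of any bearing step, compound 3 is expected to stay near compound 1, with a step of a 1.0-fold lower number from compound 1 to compound 3 (0.01 log units; within the scatter) not beyond the scatter. The estimate for compound 3 in this assay is therefore 1300 nM, within a range from 350 nM to 5000 nM.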

Compound 3, inhibition constant: < 10000 nM
Compound 3: only a limit was reported; the forecaster's own chance of this, stated with the estimate: 5%; the middle value is on the limit's open side.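

Compound 3 gives only a limit in this assay (< 10000 nM), so the step from compound 1 to compound 3 cannot be read. The compounds shown leave open whether trifluoromethyl in place of fluoro raises or lowers the number in this assay, and by how much.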